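The source may hold more compounds than are shown below. What is called first, only, known or untested is meant among the compounds shown, and "the series" means these compounds.

Compound 1 `CCCNC(=O)c1cccc2nc(OCC)n(Cc3ccc(-c4ccccc4-c4nnn[nH]4)cc3)c12`: 32.6%
Compound 2 `CCOc1nc2cccc(C(=O)N[C@H]3CC[C@H](C(=O)OC)CC3)c2n1Cc1ccc(-c2ccccc2-c2nnn[nH]2)cc1`: 28.6%
Compound 3 `CCOc1nc2cccc(C(=O)Nc3ccc(F)cc3)c2n1Cc1ccc(-c2ccccc2-c2nnn[nH]2)cc1`: 45.3%

In an assay on isolated protein for inhibition of NEDD8-activating enzyme E1 regulatory subunit (Homo sapiens), read by Western blot, with stated times of 10 min and 30 min, tested at 25 uM (on this read-out higher numbers stand for more inhibition at the one concentration tested (going by the name of the read-out) and lower numbers for less inhibition), compound 3 stands highest of the three measured compounds: the steps of a number 12.7 percentage points higher from compound 1 to compound 3 (beyond the scatter) and a number 16.7 percentage points higher from compound 2 to compound 3 (beyond the scatter) both lie beyond the scatter. Compound 4 `CCOc1nc2cccc(C(=O)Nc3ccncc3)c2n1Cc1ccc(-c2ccccc2-c2nnn[nH]2)cc1` differs from compound 3 in one place, (pyridin-4-yl in place of 4-fluorophenyl on an amide-type nitrogen). Both measured steps that reach compound 3 replace a propyl or a 4-(methoxycarbonyl)cyclohexyl group with a 4-fluorophenyl ring, so they show an aromatic ring on the amide-type nitrogen being read as more inhibition than those groups. Within the data shown here, no measured step swaps one aromatic ring for another, so the present change is not covered directly. The expectation is therefore a step of a number 5.3 percentage points lower from compound 3 to compound 4 (within the scatter), not beyond the scatter. Compound 4 is estimated at 40%, with a range from 25% to 55%.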

Compound 4, a percentage reported as inhibition, at one concentration (the size of the read-out at that concentration, not a potency): 39.8%
Compound 4: middle estimate off by 0.2 percentage points, on the high side, within the range that was stated.
By their numbers in this assay, from the lowest: compounds 2, 1, 4 and 3 (each within the scatter of the next, the first and the last beyond it).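

Among these compounds, this is the first swap of one aromatic ring for another on the amide-type nitrogen: in this assay, pyridin-4-yl in place of 4-fluorophenyl gives a number 5.5 percentage points lower from compound 3 to compound 4 (within the scatter), so this change of ring leaves the reading within the scatter. Among the compounds shown here, the pyridin-4-yl ring is clearly separated from only one non-aromatic group, with a number 11.2 percentage points higher from compound 2 to compound 4 (beyond the scatter) but a number 7.2 percentage points higher from compound 1 to compound 4 (within the scatter), whereas compound 3 stands clear of both. No measurement shown explains these results.

Still open, going by these compounds, is how an amine, a carboxylic acid or a longer chain on this nitrogen would read.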